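A few compounds are considered here, and "the series" means these few. Any claim that something is new, unique, unknown or untested is made for them only; others in the source may bear on it.

Compound 1 (`CC(C(=O)NCc1ccc(F)cc1)S(=O)(=O)c1ccc(Cl)cc1Cl`) and compound 2 (`CC(Cc1ccc(Cl)cc1Cl)C(=O)NCc1ccc(F)cc1`) offer no reading to build on. In an ADME assay on CHO cells (Cricetulus griseus) for cytotoxicity, read by LDH release (a higher number here means a weaker inhibitor, a lower number a stronger inhibitor), compound 1 is recorded as "not determined" (no result reported). Compound 2 is likewise recorded as "not determined" (no result reported). Going by the values given here, compound 3 (`CC(Oc1ccc(Cl)cc1Cl)C(=O)NC(C)c1ccc(F)cc1`) is therefore the only compound with a reported result in this assay. Compound 3 gives > 100000 nM, which is a limit of the assay and not a number. For compound 3, the data show (the limit of > 100000 nM in this assay, at which 1 of the 3 values shown sits). Among the compounds with values here, with no exact value and no measured structural step available, its standing relative to the other two compounds cannot be ranked.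

Compound 4 (`CC(Oc1ccc(Cl)cc1Cl)C(=O)N[C@H](C)c1ccc(F)cc1`) is the next compound to be tested. The change is confined to stereochemistry: the two compounds have the same atoms and bonds; at least one stereo element is drawn with a configuration in one of them and without one in the other: 1 of 2 stereo elements differ; a stereocentre at a saturated chain carbon is drawn without a configuration in compound 3 and R in compound 4. The two compounds have the same atoms and bonds, so the only difference lies in how that one stereocentre is drawn. Within the data shown here, no measured step shows what such a change does in this assay. The expectation therefore rests on compound 3 alone, with its limit of > 100000 nM. No change beyond the usual scatter is expected, and the estimated step is a number no higher from compound 3 to compound 4 (the limit leaves the size open). Compound 4 is estimated at 100000 nM, with an expected range from 50000 nM to 200000 nM.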

Compound 4, half-maximal inhibitory concentration: 97000 nM
Beside the measured number, compound 4's estimate is 1.0-fold (0.01 log units) above it, within the range that was stated.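

In this assay, going by these compounds alone, compound 4 gives 97000 nM, the first exact reading in this set. Drawing the stereocentre at the saturated chain carbon as R goes with an at least 1.0-fold lower number from compound 3 to compound 4 (0.01 log units; that floor lies within the scatter), and that size is only a floor because one end of the step is a limit: the limit of > 100000 nM in this assay, at which 1 of the 4 values shown sits. The step can be tied to that one stereocentre and to nothing else in the structure because the two compounds differ only in how it is drawn: the fact that one of compounds 3 and 4 is drawn with a defined configuration and the other without, at the place where they differ

The compounds shown leave open what the S configuration at that stereocentre would give in this assay, and so whether this stereocentre matters at all in this assay. They also leave open how the shared core would read with an amine or a carboxylic acid on it.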